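Removing the Aryl Ketone from an Acid Ceramidase Inhibitor

The source may report more compounds than this note shows. Statements on the series, on what has been measured and on what is new or still open speak of the compounds shown alone.

Measured so far in an assay on HEK293 cells for inhibition of acid ceramidase (Homo sapiens), with a stated time of 10 min; a lower number here means a stronger inhibitor, a higher number a weaker inhibitor:
- compound 1 , `COc1ccc(-c2ccc3c(c2)oc(=O)n3C(=O)NCCCCc2ccccc2)cc1`: 67 nM
- compound 2 , `O=C(NCCCCc1cccs1)n1c(=O)oc2ccccc21`: 37 nM
- compound 3 , `O=C(c1ccc(Cl)cc1)c1ccc2c(c1)oc(=O)n2C(=O)NCCCCc1ccccc1`: 14 nM

Compound 3 has the lowest number of the three, and so is the strongest inhibitor shown; compound 2 comes nearest, compound 1 sits furthest away. Compound 4 , `O=C(NCCCCc1ccccc1)n1c(=O)oc2ccccc21`, differs from compound 3 in one place: hydrogen in place of (4-chlorophenyl)carbonyl on an aromatic carbon. Going by the values given here, only one measured step touches that position, the swap from compound 1 to compound 3 , which gave a 4.8-fold lower number from compound 1 to compound 3 (0.68 log units; beyond the scatter). That step exchanged one group for another; here the group is taken away altogether, so the step does not carry over directly. Compound 2 , which carries a bare core and a closely related chain, gives 37 nM, and that value is the best guide. A modest rise in the number is therefore expected, a 2.9-fold higher number from compound 3 to compound 4 (0.46 log units; beyond the scatter). Compound 4 is estimated to give 40 nM in this assay, with a likely range of 15 nM to 110 nM.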

Compound 4, half-maximal inhibitory concentration: 64 nM
Beside the measured number, compound 4's estimate is 1.6-fold (0.20 log units) below it; the measured number falls inside the stated range.
By their numbers in this assay, from the lowest: compound 3; then compounds 2, 4 and 1 (each within the scatter of the next).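

Taking the (4-chlorophenyl)carbonyl off this aromatic carbon gives a 4.6-fold higher number from compound 3 to compound 4 (0.66 log units; beyond the scatter) and shows directly that this group, compared with bare hydrogen, goes with a lower number. Not every group here does the same: a 1.0-fold lower number from compound 1 to compound 4 (0.02 log units; within the scatter) shows that 4-methoxyphenyl and hydrogen cannot be told apart. With hydrogen on this carbon, the end of the chain also makes no clear difference, since phenyl in place of thiophen-2-yl gives a 1.7-fold higher number from compound 2 to compound 4 (0.24 log units; within the scatter) and stays inside the usual scatter of the assay.

Still open, from the compounds shown here alone, is which part of the departing group matters: the carbonyl, the ring or the chlorine, a question that a benzoyl group or a 4-chlorophenyl group without the carbonyl could test. Nothing available explains why these groups differ.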